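Adding methoxy to compound 3: what to expect

The source may report more compounds than this note shows. Statements on the series, on what has been measured and on what is new or still open speak of the compounds shown alone.

- compound 1 `O=[N+]([O-])c1cccc(-c2nn(-c3ccccc3)cc2C(Nc2nc3ccccc3s2)c2c(O)ccc3ccccc23)c1` gives 8220 nM
- compound 2 `COc1cccc(-c2nn(-c3ccccc3)cc2C(Nc2nc3ccccc3s2)c2c(O)ccc3ccccc23)c1` gives 14900 nM
- compound 3 `O=[N+]([O-])c1ccc(-c2nn(-c3ccccc3)cc2C(Nc2nc3ccccc3s2)c2c(O)ccc3ccccc23)cc1` gives 6810 nM

In a functional assay on HeLa cells (Homo sapiens) for antiproliferative activity, read by MTT assay, with a stated time of 48 h (on this read-out lower numbers stand for stronger inhibition and higher numbers for weaker inhibition), compound 3 gives 6810 nM and has one close neighbour and one more distant one in this small set. The close one appears in a 1.2-fold lower number from compound 1 to compound 3 (0.08 log units; within the scatter) and the distant one in a 2.2-fold lower number from compound 2 to compound 3 (0.34 log units; beyond the scatter) among the three measured compounds.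

Compound 4 `COc1ccc2nc(NC(c3cn(-c4ccccc4)nc3-c3ccc([N+](=O)[O-])cc3)c3c(O)ccc4ccccc34)sc2c1` carries a single change from compound 3: methoxy in place of hydrogen on an aromatic carbon with methoxy in place of hydrogen on an aromatic carbon, turning 1,3-benzothiazol-2-yl into 6-methoxy-1,3-benzothiazol-2-yl.

Going by the values given here, no measured step touches that place. Among the compounds with values here, the only step that brings in methoxy is a 1.8-fold higher number from compound 1 to compound 2 (0.26 log units; within the scatter) and it replaces nitro at another place, so it bears on this change only loosely. No step beyond the scatter is therefore expected in this assay for the new group. The expected step is a 1.0-fold higher number from compound 3 to compound 4 (0.01 log units; within the scatter) and this remains an estimate. Compound 4 is estimated at 7000 nM with an expected range from 3000 nM to 16000 nM for this measurement.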

Compound 4, half-maximal inhibitory concentration: 5540 nM
Compound 4: the middle estimate sits 1.3-fold (0.10 log units) above what was measured; the range from low to high includes it.
By their numbers in this assay, from the lowest: compounds 4, 3, 1 and 2 (each within the scatter of the next, the first and the last beyond it).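

In this assay, turning 1,3-benzothiazol-2-yl into 6-methoxy-1,3-benzothiazol-2-yl gives a 1.2-fold lower number from compound 3 to compound 4 (0.09 log units; within the scatter) and so leaves compound 3 and compound 4 indistinguishable in this measurement. The earlier compounds shown here differed only in the nitrophenyl or methoxyphenyl group, whereas this pair shows that the benzothiazole part of the shared core can carry a methoxy group on this aromatic carbon with no step beyond the scatter. No measurement shown here offers an explanation for this result.

The compounds shown leave open whether an amine or a carboxylic acid on the same aromatic carbon would also stay within the scatter. They also leave open whether the methoxy group would give a similar step alongside the 3-nitrophenyl group of compound 1.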